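The source may hold more compounds than are shown below. What is called first, only, known or untested is meant among the compounds shown, and "the series" means these compounds.

Compound 1 `OC1CCN(c2ccc(-c3ccccc3Cl)nn2)CC1` is the starting point. In a functional assay on the whole organism with Mus musculus as the target (on this read-out higher numbers stand for an effect only at larger amounts of compound and lower numbers for an effect already at smaller amounts), compound 1 gives 38 mg/kg. Compound 2 `OC1CCN(c2ccc(-c3cc(Cl)ccc3Cl)nn2)CC1` differs from it by chloro in place of hydrogen on an aromatic carbon; in this assay compound 2 gives 131 mg/kg, a shift of a 3.4-fold higher number from compound 1 to compound 2 (0.54 log units; beyond the scatter). Compound 3 `CNC(=O)OC1CCN(c2ccc(-c3ccccc3Cl)nn2)CC1` has a different core, differing from compound 1 by methylcarbamoyl in place of hydrogen on an oxygen on a saturated carbon; in this assay compound 3 gives 13 mg/kg, a shift of a 2.9-fold lower number from compound 1 to compound 3 (0.47 log units; beyond the scatter). Compound 4 `CNC(=O)OC1CCN(c2ccc(-c3ccc(Cl)cc3Cl)nn2)CC1` differs from compound 3 by chloro in place of hydrogen on an aromatic carbon. This is the same kind of change as from compound 1 to compound 2, but not the same: there the entering chloro sat meta to a large group and para to a chloro group, here it sits meta to a chloro group and para to a large group. The earlier step of this kind was a 3.4-fold higher number from compound 1 to compound 2 (0.54 log units; beyond the scatter). On that basis the expected step is a 2.7-fold higher number from compound 3 to compound 4 (0.43 log units; beyond the scatter), widened for the changed place. Compound 4 is expected to give 35 mg/kg, between 12 mg/kg and 100 mg/kg.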

Compound 4, dose for half-maximal effect: 1.4 mg/kg
The estimate for compound 4 lay 25-fold (1.40 log units) above the measured number; the measured number lies below the stated range.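

Here, chloro in place of hydrogen on an aromatic carbon gives a 9.3-fold lower number from compound 3 to compound 4 (0.97 log units; beyond the scatter) in this assay. Set beside the earlier step, the same kind of change runs in opposite directions on the two cores: the same change on two cores in this assay, a 3.4-fold higher number (0.54 log units; beyond the scatter) from compound 1 to compound 2 and a 9.3-fold lower number (0.97 log units; beyond the scatter) from compound 3 to compound 4, 32-fold (1.51 log units) apart, beyond the scatter of two such steps. This shows that the effect of adding a chloro cannot simply be carried from one core to the other, but the chloro also enters at a different place in the two steps, so it does not show whether the core, the place or both account for the gap.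

The compounds shown leave open what a chloro in the place it holds in compound 4 would do on the core of compound 1, a comparison that would separate these two factors. They also leave open whether a fluoro or methoxy group in that place, or ethylcarbamoyl in place of methylcarbamoyl, would give a similarly low number.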